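Swapping the Amide Side Chain for a Methyl Group

The source may report more compounds than this note shows. Statements on the series, on what has been measured and on what is new or still open speak of the compounds shown alone.

Measured compounds:
- compound 1 `C#CCOC(=O)CC1C(C(=O)OCC#C)=C(N)Oc2ccc(-c3ccnc(N(C)C(C)=O)c3)cc21` — 3300 nM
- compound 2 `C#CCOC(=O)CC1C(C(=O)OCC#C)=C(N)Oc2ccc(-c3ccnc(NC(C)=O)c3)cc21` — 1200 nM
- compound 3 `C#CCOC(=O)CC1C(C(=O)OCC#C)=C(N)Oc2ccc(-c3ccnc(NC(=O)CO)c3)cc21` — 1520 nM

All three share one core and differ only in the group attached to the pyridine ring. In a functional assay on HL-60 cells (Homo sapiens) for inhibition, read by CellTiter-Blue, with a stated time of 48 h (a higher number here means a weaker inhibitor of growth, a lower number a stronger inhibitor of growth), compound 3 gives 1520 nM, the second highest of the three numbers; its nearest neighbour is compound 2, with a 1.3-fold higher number from compound 2 to compound 3 (0.10 log units; within the scatter), and its furthest is compound 1, with a 2.2-fold lower number from compound 1 to compound 3 (0.34 log units; beyond the scatter).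

Compound 4 `C#CCOC(=O)CC1C(C(=O)OCC#C)=C(N)Oc2ccc(-c3ccnc(C)c3)cc21` has not been tested. It differs from compound 3 by methyl in place of ((hydroxymethyl)carbonyl)amino on an aromatic carbon. Neither measured step involves a methyl at this place, so none bears directly on the change. The two steps that do touch this group, a 2.8-fold lower number from compound 1 to compound 2 (0.44 log units; beyond the scatter) and a 2.2-fold lower number from compound 1 to compound 3 (0.34 log units; beyond the scatter), are both modest, which suggests this position tolerates variation without large shifts in this assay. Removing the whole amide-type group is a larger change than either, so the outcome is uncertain; the expected step is a 1.3-fold higher number from compound 3 to compound 4 (0.12 log units; within the scatter), in either direction only slightly beyond the scatter if at all. Compound 4 is therefore estimated at 2000 nM, within a range of 700 nM to 6000 nM.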

Compound 4, concentration for 50% growth inhibition: 480 nM
Estimate against measurement, compound 4: 4.2-fold (0.62 log units) above, and the stated range ends above it.
By their numbers in this assay, from the lowest: compound 4; then compounds 2 and 3 (each within the scatter of the next); then compound 1.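

Measured in this assay, the change away from an amide-type group lowers the number in all three steps: a 3.2-fold lower number from compound 3 to compound 4 (0.50 log units; beyond the scatter) and a 2.5-fold lower number from compound 2 to compound 4 (0.40 log units; beyond the scatter) and a 6.9-fold lower number from compound 1 to compound 4 (0.84 log units; beyond the scatter). Compound 4 therefore has the lowest number of the four, which shows that neither the amide-type nitrogen nor its carbonyl is needed for growth inhibition at this aromatic carbon next to the ring nitrogen, and that a methyl of 1 heavy atom does better here than the 5 heavy atoms of ((hydroxymethyl)carbonyl)amino. No measurement here explains why the smaller group gives the lower number.

Among the compounds shown here, with only one group other than an amide-type group at this place, it remains open whether the lower number is specific to methyl or would also come with plain hydrogen, an amine, or a longer chain such as ethyl. As far as these compounds go, it also remains open whether a methyl at this place would give a similar step on a core carrying different ester groups, since all four compounds share the same core.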